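This account rests on a few compounds, and the source may have more. Where it says the series, first, only, none or still open, it means among the compounds named here.

Two compounds share one core and differ only in the group attached at a carbonyl carbon. Compound 1 `CNC(=O)c1cc(Oc2ccc3nc(NC(=O)c4cc(Cl)cc(Cl)c4)sc3c2)ccn1` carries a 3,5-dichlorophenyl there, and in a functional assay on SK-BR-3 cells (Homo sapiens) for inhibition, read by MTT assay, with a stated time of 2 days, tested at 100 uM (a higher number here means more inhibition of growth at the concentration tested, a lower number less inhibition of growth), compound 1 gives 84.3%. Compound 2 `CNC(=O)c1cc(Oc2ccc3nc(NC(=O)Nc4ccc(F)cc4)sc3c2)ccn1` carries a (4-fluorophenyl)amino instead, and in this assay compound 2 gives 72.9%. Among the compounds with values here, the single measured step, a number 11.4 percentage points lower from compound 1 to compound 2 (beyond the scatter), leaves compound 2 as the lower of the two numbers. Compound 3 `CNC(=O)c1cc(Oc2ccc3nc(NC(=O)Nc4ccc(Cl)cc4Cl)sc3c2)ccn1` is not yet measured; its change from compound 2 is 2,4-dichlorophenyl in place of 4-fluorophenyl on an amide-type nitrogen. Within the data shown here, no measured step swaps one halogenated phenyl for another on the same amide-type nitrogen, so the only guide is a number 11.4 percentage points lower from compound 1 to compound 2 (beyond the scatter), a modest step in which a dichlorophenyl-bearing compound stood higher, although that step also changed the link between the carbonyl and the ring. The expected step in this assay is therefore small and upward, a number 5.1 percentage points higher from compound 2 to compound 3 (within the scatter), and may well stay within the scatter. Compound 3 is estimated at 78%, with a range from 64% to 90%.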

Compound 3, percent growth inhibition at one concentration: 91.7%
Compound 3: middle estimate off by 13.7 percentage points, on the low side, outside the stated range (above it).
By their numbers in this assay, from the lowest: compound 2; then compounds 1 and 3 (each within the scatter of the next).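

On the amide-type nitrogen, with the link to the carbonyl held the same, 2,4-dichlorophenyl in place of 4-fluorophenyl gives a number 18.8 percentage points higher from compound 2 to compound 3 (beyond the scatter) in this assay, so the phenyl group on this nitrogen can by itself move the number beyond the scatter. On the carbonyl carbon, (2,4-dichlorophenyl)amino in place of 3,5-dichlorophenyl gives a number 7.4 percentage points higher from compound 1 to compound 3 (within the scatter) and so no order can be set between these two compounds, which means that the lower number of compound 2 cannot be pinned on the amino link alone. The data shown offer no independent measurement that would explain why the 2,4-dichlorophenyl change raises the number.

The compounds shown leave open whether the gain follows the number of chlorines, their places on the ring or the swap of fluorine for chlorine, and a (2-chlorophenyl)amino or (4-chlorophenyl)amino group would help to separate these. On these data alone, all the phenyl groups here carry only halogens, so it also stays open how a phenyl ring bearing a methoxy group or an amine would read in this assay on the same nitrogen.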